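The compounds below may be only part of what the source reports. "The series", "measured", "known", "first", "only" and "open" are said of these compounds alone.

Compound 1 `COc1ccc(-c2cnc(NC(=O)c3ncc[nH]3)n2C)cc1` is one of three compounds tested in a toxicity assay on THP-1 cells (Homo sapiens) for inhibition; a lower number here means that less compound is tolerated, a higher number that more compound is tolerated. Compound 1 reaches only the assay limit there, giving > 100000 nM. Compound 2 `Cc1ccccc1C(=O)Nc1ncc(-c2ccccc2)n1C` likewise gives a limit of > 100000 nM. Compound 3 `Cn1c(-c2ccc(Br)cc2)cnc1NC(=O)c1ccc(F)cc1`, by contrast, gives a numerical value of 46000 nM. Within the data shown here, compound 1 thus sits at the limit of > 100000 nM in this assay, at which 2 of the 3 values shown sit, and no two measured compounds differ in just one place, so no single measured step is known. Compound 4 `COc1ccc(-c2cnc(NC(=O)c3ccno3)n2C)cc1` differs from compound 1 by 1,2-oxazol-5-yl in place of 1H-imidazol-2-yl on a carbonyl carbon. Among the measured compounds shown here, with the starting point a limit and no measured step to draw on, no shift beyond the usual scatter is expected in this assay. The expected step from compound 1 to compound 4 is a number no higher from compound 1 to compound 4 (the limit leaves the size open). Compound 4 is therefore estimated at 100000 nM, between 30000 nM and 300000 nM.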

Compound 4, half-maximal cytotoxic concentration: > 100000 nM
Compound 4 gave a limit, no number; the forecaster's own chance of this, stated with the estimate: 60%; the middle value sits exactly at the limit.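

Compound 1 and compound 4 each give only a limit in this assay, and the step between them cannot be read. The compounds shown leave open whether 1,2-oxazol-5-yl in place of 1H-imidazol-2-yl on a carbonyl carbon shifts the half-maximal cytotoxic concentration at all.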